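Chain extension and a selenocyanate in place of bromine

This account rests on a few compounds, and the source may have more. Where it says the series, first, only, none or still open, it means among the compounds named here.

Compound 1 `COc1ccc(N(C)c2ccnc(Cl)n2)cc1O` carries a free hydroxyl on the ring bearing the methoxy group, and in a functional assay on HeLa cells (Homo sapiens) for antiproliferative activity, read by MTT assay, with a stated time of 48 h (on this read-out higher numbers stand for weaker inhibition and lower numbers for stronger inhibition), compound 1 gives 96 nM. Compound 2 `COc1ccc(N(C)c2ccnc(Cl)n2)cc1OCCCCCBr` carries the 5-bromopentyl chain on that oxygen instead, and in this assay compound 2 gives 7090 nM. Among the measured compounds shown here, the only measured step is a 74-fold higher number from compound 1 to compound 2 (1.87 log units; beyond the scatter), so compound 2 holds the highest of the two numbers seen, with compound 1 far below it.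

Compound 3 `COc1ccc(N(C)c2ccnc(Cl)n2)cc1OCCCCC[Se]C#N` keeps the whole of compound 2 and changes only the end of the chain: a group of 3 heavy atoms (1 carbon, 1 nitrogen, 1 selenium; no ring) in place of one bromine atom, on a saturated chain carbon, five bonds along the chain from an oxygen on an aromatic ring. For the measured compounds named here, no measured pair bears directly on this exchange; the one step seen concerns adding the chain itself, not what sits at its end. With nothing to anchor the direction, a modest move is expected, somewhat more likely toward a lower number, and compound 3 is therefore estimated to sit at 3500 nM with a range from 600 nM to 15000 nM, which means an expected step of a 2.0-fold lower number from compound 2 to compound 3 (0.31 log units; beyond the scatter).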

Compound 3, half-maximal inhibitory concentration: > 10000 nM
Compound 3: a limit, no number; the forecaster's own chance of this, stated with the estimate: 5%; middle value at least 2.8-fold (0.45 log units) away from the limit.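

In this assay, compound 3 is reported only as a limit of the assay and not as a number: the limit of > 10000 nM in this assay, at which 1 of the 3 values shown sits.

Replacing the bromine at the end of the chain with the selenocyanate gives an at least 1.4-fold higher number from compound 2 to compound 3 (0.14 log units; that floor lies within the scatter), and because that floor lies within the scatter, the change cannot be said to separate the two compounds by more than repeated measurements might, although it shows no gain from the selenocyanate at this place, five bonds along the chain from an oxygen on an aromatic ring. Measured against the free hydroxyl, the chain with this new end gives an at least 100-fold higher number from compound 1 to compound 3 (2.01 log units; beyond the scatter), so a second chain end, after the bromine, also stands far from the hydroxyl compound on this read-out.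

From the compounds shown here alone, how far compound 3 lies past its limit remains unknown, and so does the true size of the step from the bromine to the selenocyanate. Also open, going by these compounds, is whether a shorter chain such as ethyl, or an amine or a carboxylic acid at the end of the pentyl chain, would bring the number back toward compound 1 and its 96 nM.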